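The source may report more compounds than this note shows. Statements on the series, on what has been measured and on what is new or still open speak of the compounds shown alone.

Two compounds of the shared core have numbers in an assay on CHO cells for agonist activity at transient receptor potential cation channel subfamily V member 1 (Homo sapiens); a lower number here means that less compound is needed, a higher number that more compound is needed for the effect. Compound 1 `CC1CCN(c2nc(C(F)(F)F)ccc2CNC(=O)Nc2cccc3c(=O)[nH]ccc23)CC1` gives 9.59 nM. For the measured compounds named here, compound 2 `CCCCOc1nc(C(F)(F)F)ccc1CNC(=O)Nc1cccc2c(=O)[nH]ccc12` gives 160 nM, the higher of the two numbers; the only step, a 17-fold higher number from compound 1 to compound 2 (1.22 log units; beyond the scatter), is large and lies beyond the scatter. Compound 3 `CC(C)COc1nc(C(F)(F)F)ccc1CNC(=O)Nc1cccc2c(=O)[nH]ccc12` is not yet measured. Compound 3 differs from compound 2 by isopropyl in place of propyl on a saturated chain carbon bound to an oxygen on an aromatic ring. Going by the values given here, the one measured step exchanges a ring amine for an open chain on the aromatic carbon and says nothing about how a branch within the chain, isopropyl in place of propyl, moves this assay; no step of that kind exists. With nothing to point either way, the expected step of no change at the digits printed from compound 2 to compound 3 (within the scatter) is none beyond the scatter. Compound 3 is therefore estimated at 160 nM in this assay, with a range from 55 nM to 470 nM.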

Compound 3, half-maximal effective concentration: 78.7 nM
For compound 3 the middle estimate is 2.0-fold (0.31 log units) above the measured one; the range from low to high includes it.
By their numbers in this assay, from the lowest: compound 1; then compound 3; then compound 2.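

In this assay the change from butoxy to isobutoxy gives a 2.0-fold lower number from compound 2 to compound 3 (0.31 log units; beyond the scatter) at this position, so the number responds to branching within the open chain and not only to the exchange of a ring amine for a chain. The branch closes only part of the gap, since isobutoxy in place of 4-methylpiperidin-1-yl still leaves an 8.2-fold higher number from compound 1 to compound 3 (0.91 log units; beyond the scatter) and compound 1 remains lowest of the three. Nothing at hand accounts for the effect of the branch.

Open, going by these compounds, is whether a further branched chain such as neopentyloxy, or a cyclopropylmethoxy group, would lower the number further. Also open, on these data alone, is whether an open-chain amine such as dibutylamino would give a number closer to that of compound 1 or to those of the two ethers.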